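Adding fluorine to the benzyl group of compound 2

A few compounds are considered here, and "the series" means these few. Any claim that something is new, unique, unknown or untested is made for them only; others in the source may bear on it.

Compound 1 `O=C(Nc1ccc(-c2cscn2)cc1)[C@@H]1CCCN(Cc2ccc(F)c(F)c2)C1` gives 4000 nM
Compound 2 `O=C(Nc1ccc(-c2cscn2)cc1)C1CCCN(Cc2ccccc2F)C1` gives 7000 nM

In a functional assay on A-375 cells (Homo sapiens) for activation, with a stated time of 3 days (a higher number here means that more compound is needed for the effect, a lower number that less compound is needed), compound 2 gives 7000 nM and stands within the scatter of compound 1 (4000 nM). Compound 3 `O=C(Nc1ccc(-c2cscn2)cc1)C1CCCN(Cc2cc(F)c(F)c(F)c2)C1` differs from compound 2 by 3,4,5-trifluorophenyl in place of 2-fluorophenyl on a saturated chain carbon bound to an amine nitrogen in a ring on a saturated chain carbon bound to an amine nitrogen in a ring. With compound 2 at 7000 nM and compound 1 at 4000 nM inside the scatter of each other, no step beyond the scatter is expected in this assay in either direction. The expected step is a 1.6-fold lower number from compound 2 to compound 3 (0.19 log units; within the scatter) and would stay within the scatter. Compound 3 is estimated at 4500 nM with 1500 nM to 13000 nM as its expected range.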

Compound 3, half-maximal effective concentration: 1260 nM
Compound 3: the middle estimate sits 3.6-fold (0.55 log units) above what was measured; measured number below the stated range.
By their numbers in this assay, from the lowest: compound 3; then compounds 1 and 2 (each within the scatter of the next).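

For the compounds shown here, the change from 2-fluorobenzyl to 3,4,5-trifluorobenzyl brings a 5.6-fold lower number from compound 2 to compound 3 (0.74 log units; beyond the scatter) in this assay and is the first step beyond the scatter here. Going by these compounds alone, it shows that the number responds to the fluorine pattern on this phenyl group, which the earlier compounds, within the scatter of each other, could not show. No measurement shown accounts for the size of this step.

Compound 2 and compound 3 differ in both the count of fluorine atoms and their places, and the compounds shown do not separate the two. Also open, as far as these compounds go, is how a nitrile or a methoxy group on this phenyl ring would read.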